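The compounds below may be only part of what the source reports. "The series", "measured", "known", "first", "only" and "open" are said of these compounds alone.

Compound 1, `CN(C)CCCCn1c(N)c(-c2nc3ccccc3n2C)c2nc(C#N)c(C#N)nc21`, and compound 2, `CCN(CC)CCCCn1c(N)c(-c2nc3ccccc3n2C)c2nc(C#N)c(C#N)nc21`, share one core and differ in a single spot: diethylamino in place of dimethylamino on a saturated chain carbon, four bonds along the chain from an aromatic nitrogen. In a functional assay on HL60/MX2 cells (Homo sapiens) for antiproliferative activity, read by MTT assay, with a stated time of 48 h (a higher number here means a weaker inhibitor, a lower number a stronger inhibitor), compound 1 gives 2580 nM, and in this assay compound 2 gives 1730 nM, so that a 1.5-fold lower number from compound 1 to compound 2 (0.17 log units; within the scatter). Compound 3, `CN(C)CCCn1c(N)c(-c2nc3cc(Cl)ccc3[nH]2)c2nc(C#N)c(C#N)nc21`, is built on another core; the difference between the two cores is not broken down here. In this assay compound 3 gives 5310 nM, the highest of the three numbers. Compound 4, `CCN(CC)CCCn1c(N)c(-c2nc3cc(Cl)ccc3[nH]2)c2nc(C#N)c(C#N)nc21`, arises from compound 3 by the same kind of change, (diethylamino in place of dimethylamino on a saturated chain carbon, three bonds along the chain from an aromatic nitrogen); the place differs in that the amine sits three bonds along the chain from the aromatic nitrogen, not four. Because a 1.5-fold lower number from compound 1 to compound 2 (0.17 log units; within the scatter) lay within the scatter, for compound 4 a similarly small step is expected, a 1.4-fold lower number from compound 3 to compound 4 (0.15 log units; within the scatter). Compound 4 is therefore estimated at 3800 nM, likely between 1800 nM and 8000 nM.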

Compound 4, half-maximal inhibitory concentration: 2460 nM
Compound 4: middle estimate off by 1.5-fold (0.19 log units), on the high side; the measured number falls inside the stated range.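

In this assay, diethylamino in place of dimethylamino gives a 2.2-fold lower number from compound 3 to compound 4 (0.33 log units; beyond the scatter). Within the data shown here, although only this step lies beyond the scatter, the two steps cannot be told apart, so the change carries over from one core to the other at about the same size: the same change on two cores in this assay, a 1.5-fold lower number (0.17 log units; within the scatter) from compound 1 to compound 2 and a 2.2-fold lower number (0.33 log units; beyond the scatter) from compound 3 to compound 4, 1.4-fold (0.16 log units) apart, within the scatter of two such steps. Among these compounds, this rests on only two pairs, which also differ in how far the amine sits along the chain, so it does not show that the step would hold on further cores or chains.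

Still open, going by these compounds, is whether a larger dipropylamino group or a primary amine at this place would continue the same trend. On these data alone, a longer chain on the core of compound 3 also remains open.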